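Dropping the amino group from a chloropurine analogue

A few compounds are considered here, and "the series" means these few. Any claim that something is new, unique, unknown or untested is made for them only; others in the source may bear on it.

Three compounds with a shared core and a chloromethylbenzyl group have been measured in a functional assay on IGROV-1 cells (Homo sapiens) for cytotoxicity, read by sulforhodamine B assay, with a stated time of 48 h; a higher number here means a weaker inhibitor of growth, a lower number a stronger inhibitor of growth. Compound 1 `Nc1nc(Cl)c2ncn(Cc3ccccc3CCl)c2n1` gives 6310 nM. Compound 2 `ClCc1cccc(Cn2cnc3nc(Cl)nc(Cl)c32)c1` gives 17000 nM, a number beyond the scatter above that of compound 1, so compound 2 inhibits growth more weakly. Compound 3 `ClCc1ccccc1Cn1cnc2ncnc(Cl)c21` gives 4260 nM, which lies within the scatter of the number for compound 1. Compound 1 thus stands second highest of the three, nearest to compound 3 and furthest from compound 2.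

The next compound, compound 4 `ClCc1ccccc1Cn1cnc2c(Cl)ncnc21`, differs from compound 1 in one place: hydrogen in place of amino on an aromatic carbon. For the measured compounds named here, no pair of measured compounds here differs by the same change, so its effect is not known from the data. Compound 3, which also lacks the amino group, gives 4260 nM, a number within the scatter of compound 1, and on that basis the step from compound 1 to compound 4 is expected to be small, a 1.3-fold lower number from compound 1 to compound 4 (0.12 log units; within the scatter), with no direction beyond the scatter. Compound 4 is therefore estimated to give 4800 nM in this assay, within a range of 2000 nM to 12000 nM.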

Compound 4, concentration for 50% growth inhibition: 3160 nM
The estimate for compound 4 lay 1.5-fold (0.18 log units) above the measured number; the range from low to high includes it.
By their numbers in this assay, from the lowest: compounds 4, 3 and 1 (each within the scatter of the next); then compound 2.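

For the compounds shown here, this is the first step that can be read directly, and it concerns the aromatic carbon between two ring nitrogen atoms. In this assay, hydrogen in place of amino at that carbon gives a 2.0-fold lower number from compound 1 to compound 4 (0.30 log units; within the scatter), so losing the amino group, with its hydrogen-bond donor and acceptor, does not shift the number beyond the scatter. No separate measurement bears on this result.

The compounds shown leave open whether a different group on this carbon, such as methoxy or dimethylamino, would give a number beyond the scatter. They also leave open whether the same exchange would have as small an effect with the chloromethyl group placed on the benzyl ring as it is in compound 2.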